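A few compounds are considered here, and "the series" means these few. Any claim that something is new, unique, unknown or untested is made for them only; others in the source may bear on it.

Measured compounds:
- Compound 1 `COc1ccc(/C=C\c2cc(OC)c(OC)c(OC)c2)cc1OCc1ccc(CNC(C)(C)C(=O)O)cc1`: in an ADME assay on HEK293 cells (Homo sapiens) for cytotoxicity, read by CCK-8 assay, with a stated time of 48 h (a higher number here means a weaker inhibitor, a lower number a stronger inhibitor), compound 1 gives > 50000 nM, which is a limit of the assay rather than a number.
- Compound 2 `COc1ccc(/C=C\c2cc(OC)c(OC)c(OC)c2)cc1OCc1ccc(C=O)cc1`: in this assay compound 2 gives 46000 nM.
- Compound 3 `COc1ccc(/C=C\c2cc(OC)c(OC)c(OC)c2)cc1OCc1ccc(CN2CC[C@H](C(=O)O)C2)cc1`: in this assay compound 3 gives > 50000 nM, again a limit of the assay.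

Compound 1 therefore stands at the upper boundary of what the assay reports, and its true number is not known; the same holds for compound 3, as the limit of > 50000 nM in this assay, at which 2 of the 3 values shown sit, shows. The unmeasured compound 4 `COc1ccc(/C=C\c2cc(OC)c(OC)c(OC)c2)cc1OCc1ccc(CN2CC(C(=O)O)C2)cc1` differs from compound 1 in one place: 3-carboxyazetidin-1-yl in place of (1-carboxy-1-methylethyl)amino on a saturated chain carbon bound to an aromatic carbon.

The most closely related measured step is a step that the two limits leave unreadable from compound 1 to compound 3, where both ends are limits and the size cannot be read. The two steps that pass through compound 2, an at least 1.0-fold lower number from compound 1 to compound 2 (0.03 log units; that floor lies within the scatter) and an at least 1.0-fold higher number from compound 2 to compound 3 (0.03 log units; that floor lies within the scatter), are both floors that lie within the scatter. All three compounds sit at or close to the limit, so nothing here points to a change beyond the scatter, and the expected step is a step that the limit leaves unreadable from compound 1 to compound 4. Compound 4 is therefore estimated at 55000 nM, with a range from 30000 nM to 100000 nM, most likely reported as a limit.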

Compound 4, half-maximal inhibitory concentration: > 50000 nM
Compound 4 gave a limit, no number; the forecaster's own chance of this, stated with the estimate: 70%; the middle value lies beyond the limit too.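

In this assay, 3-carboxyazetidin-1-yl on the saturated chain carbon bound to an aromatic carbon brings a four-membered ring to this place, and compound 4 still gives only a limit, as compound 1 and compound 3 do. The step of an at least 1.0-fold higher number from compound 2 to compound 4 (0.03 log units; that floor lies within the scatter) is the only new one that can be read. The steps linking compound 4 with compound 1 and with compound 3 cannot be read, because both ends of each sit at one limit: the limit of > 50000 nM in this assay, at which 3 of the 4 values shown sit.

How far past that limit each of these compounds lies stays open, and so does any order among them. Also open, from the compounds shown here alone, is what an amine with no carboxylic acid, such as dimethylamino, or a longer chain between the amine and the carboxylic acid would give at this place.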